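The compounds below may be only part of what the source reports. "The series", "measured", "known", "first", "only" and "open" are said of these compounds alone.

In an ADME assay on HepG2 2.2.15 cells (Homo sapiens) for cytotoxicity, read by MTT assay (on this read-out higher numbers stand for lower toxicity in this test and lower numbers for higher toxicity in this test), compound 1 `C=C1CC[C@@H]2[C@](C)(COC(=O)c3ccco3)[C@H](O)CC[C@@]2(C)[C@@H]1C/C=C1\C=COC1=O` gives only a limit, > 2150000 nM. Compound 2 `C=C1CC[C@@H]2[C@](C)(COC(C)=O)[C@H](O)CC[C@@]2(C)[C@@H]1C/C=C1\C=COC1=O` gives 334000 nM, and compound 3 `C=C1CC[C@@H]2[C@](C)(COC(=O)CCCC)[C@H](O)CC[C@@]2(C)[C@@H]1C/C=C1\C=COC1=O` gives 225000 nM. These two numbers sit together, with a 1.5-fold lower number from compound 2 to compound 3 (0.17 log units; within the scatter). Compound 1 stands apart from both, with an at least 6.4-fold lower number from compound 1 to compound 2 (0.80 log units; beyond the scatter) and an at least 9.5-fold lower number from compound 1 to compound 3 (0.98 log units; beyond the scatter).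

Compound 4 `C=C1CC[C@@H]2[C@](C)(COC(C)=O)[C@H](OC(C)=O)CC[C@@]2(C)[C@@H]1C/C=C1\C=COC1=O` differs from compound 2 by acetyl in place of hydrogen on an oxygen on a saturated carbon, which turns hydroxy to acetoxy. Within the data shown here, no measured step touches this hydroxy. The closest guides are the changes to the existing ester, and these cut both ways: swapping one chain for another stayed within the scatter, while replacing furan-2-yl did not. A change beyond the scatter in this assay is therefore not expected, though the range stays wide. The expected step is a 1.2-fold lower number from compound 2 to compound 4 (0.08 log units; within the scatter). The estimate for compound 4 is 280000 nM, within an expected range of 110000 nM to 750000 nM.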

Compound 4, half-maximal cytotoxic concentration: 297000 nM
Beside the measured number, compound 4's estimate is 1.1-fold (0.03 log units) below it, within the range that was stated.
By their numbers in this assay, from the lowest: compounds 3, 4 and 2 (each within the scatter of the next). At a limit, above all of these: compound 1.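

Turning hydroxy to acetoxy gives a 1.1-fold lower number from compound 2 to compound 4 (0.05 log units; within the scatter) in this assay, the first look at this oxygen, since the earlier compounds varied only the other ester. Compounds 2 and 4 therefore sit together, so on this read-out the hydrogen on this oxygen is not required to keep the number where it stands in compound 2. Nothing shown gives a reason for this. As far as these compounds go, only acetyl has been seen here, so a butanoyl ester, a furan-2-carbonyl ester or a chain ending in an amine on this oxygen remains open.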